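This account rests on a few compounds, and the source may have more. Where it says the series, first, only, none or still open, it means among the compounds named here.

Measured compounds:
- compound 1 `CN(C)c1ccc(C(=O)Nc2cccc(NC(=O)COc3ccc4c(c3)CCC(=O)N4)c2)cc1` gives 9970 nM
- compound 2 `COc1ccc(OCC(=O)Nc2cccc(NC(=O)c3ccc(N(C)C)cc3)c2)cc1OC` reaches only the limit > 10000 nM
- compound 3 `CCc1ccc(C(=O)Nc2cccc(NC(=O)COc3ccc4c(=O)ccoc4c3)c2)cc1` gives 24 nM

All three were tested in an assay on isolated protein for inhibition of Rho-associated protein kinase 2 (Homo sapiens), read by scintillation counting, radiometric assay and 33P incorporation, with a stated time of 40 min, in the presence of a further agent that is not named here; a lower number here means a stronger inhibitor, a higher number a weaker inhibitor. Compound 3 stands at the lowest of the two real numbers; compound 1 sits at a higher number, a gap well beyond the scatter. Compound 2 reports only a limit, not a number. For the measured compounds named here, the single measured step, a number no lower from compound 1 to compound 2 (the limit leaves the size open), swaps the group on the oxygen of the saturated carbon, and its size cannot be read because of the limit of > 10000 nM in this assay, at which 1 of the 3 values shown sits.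

Compound 4 `CCOc1ccc(C(=O)Nc2cccc(NC(=O)COc3ccc4c(=O)ccoc4c3)c2)cc1` differs from compound 3 by ethoxy in place of ethyl on an aromatic carbon. Going by the values given here, this change sits on the far aromatic ring, a place no measured step touches, so the known steps give no direct guide to its size. An ethoxy group in place of an ethyl group is a small change in bulk, and without any measured step at that position there is no reason to expect a large shift in either direction.

The expected step of a 1.3-fold higher number from compound 3 to compound 4 (0.10 log units; within the scatter) is therefore small, within the usual scatter. Compound 4 is estimated at 30 nM, with a range from 10 nM to 100 nM.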

Compound 4, half-maximal inhibitory concentration: 9 nM
Compound 4: middle estimate off by 3.3-fold (0.52 log units), on the high side, and the stated range ends above it.
By their numbers in this assay, from the lowest: compound 4; then compound 3; then compound 1. At a limit, above all of these: compound 2.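

For the compounds shown here, the far aromatic ring, which no earlier step had touched, proves responsive in this assay: ethoxy in place of ethyl gives a 2.7-fold lower number from compound 3 to compound 4 (0.43 log units; beyond the scatter). This modest step shows that the position para to a large group accepts a chain carrying an oxygen on the aromatic carbon without any loss of inhibition, and that the added oxygen, counted as one hydrogen-bond acceptor, goes with a lower number rather than a neutral result. The compounds shown contain nothing that explains why this swap lowers the number.

A single step cannot separate the effect of the oxygen itself from that of simply having one more heavy atom in the group, and a propyl group at the same place, a chain of carbon only, would be the natural comparison for telling those two apart. Also open, as far as these compounds go, is how far this position stretches, for example whether it would take a much larger or differently charged group such as a carboxylic acid, and whether the lower number would hold on a different core.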